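Swapping 2-methylphenyl for 6-fluoropyridin-3-yl

A few compounds are considered here, and "the series" means these few. Any claim that something is new, unique, unknown or untested is made for them only; others in the source may bear on it.

In an ADME assay on CHO cells (Cricetulus griseus) for cytotoxicity, read by LDH release (on this read-out higher numbers stand for weaker inhibition and lower numbers for stronger inhibition), compound 1 `CC(Oc1ccc(Cl)cc1Cl)C(=O)NCc1cccc(F)c1` gives 27000 nM and compound 2 `CC(Oc1ccc(Cl)cc1Cl)C(=O)NCc1ccc(Cl)cc1` gives 39000 nM. Compound 3 `Cc1ccccc1CNC(=O)C(C)Oc1ccc(Cl)cc1Cl` gives > 100000 nM, which is a limit of the assay and not a number. Compound 4 `CC(Oc1ccc(Cl)cc1Cl)C(=O)NCc1ccc(F)nc1` carries 6-fluoropyridin-3-yl in place of 2-methylphenyl on a saturated chain carbon bound to an amide-type nitrogen. Measured changes at this place are an at least 3.7-fold higher number from compound 1 to compound 3 (0.56 log units; beyond the scatter) and an at least 2.5-fold higher number from compound 2 to compound 3 (0.40 log units; beyond the scatter), both beyond the scatter, while a 1.4-fold higher number from compound 1 to compound 2 (0.16 log units; within the scatter) stays within it. The entering ring carries fluorine, as in compound 1 at 27000 nM, but also a ring hetero atom absent from all measured compounds, so a move to a lower number is expected. The estimated change is an at least 2.0-fold lower number from compound 3 to compound 4 (0.30 log units; that floor lies within the scatter). For compound 4 the expected value is 50000 nM, with an estimated range of 20000 nM to 100000 nM.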

Compound 4, half-maximal inhibitory concentration: > 100000 nM
Compound 4 was reported as a limit; the forecaster's own chance of this, stated with the estimate: 30%; middle value at least 2.0-fold (0.30 log units) from the limit.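

In this assay compound 4 gives > 100000 nM, which is a limit of the assay and not a number. Fluorine on a ring with a hetero atom therefore does not bring the number down toward those of the 3-fluorophenyl and 4-chlorophenyl compounds, with an at least 3.7-fold higher number from compound 1 to compound 4 (0.56 log units; beyond the scatter) and an at least 2.5-fold higher number from compound 2 to compound 4 (0.40 log units; beyond the scatter). The step between compound 3 and compound 4 cannot be read: the limit of > 100000 nM in this assay, at which 2 of the 4 values shown sit.

From the compounds shown here alone, how far compound 3 and compound 4 actually lie apart remains open. Also open, going by these compounds, is whether an amine on the pyridine ring or a longer chain at this place would move the number away from that limit.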